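This account rests on a few compounds, and the source may have more. Where it says the series, first, only, none or still open, it means among the compounds named here.

Measured so far:
compound 1, `O=C(/C=C/c1coc2cc(O)ccc2c1=O)NCc1ccc(F)cc1`: > 100000 nM
compound 2, `COc1ccc2c(=O)c(/C=C/C(=O)NCc3cccc(F)c3)coc2c1`: 26900 nM
compound 3, `Cc1ccccc1NC(=O)/C=C/c1coc2cc(O)ccc2c1=O`: > 100000 nM

In a functional assay on A549 cells (Homo sapiens) for inhibition, read by MTT assay, with a stated time of 48 h (on this read-out higher numbers stand for weaker inhibition and lower numbers for stronger inhibition), compound 2 gives 26900 nM. For compound 1 the read-out is only a limit, > 100000 nM. For compound 3 the read-out is likewise a limit, > 100000 nM. For the measured compounds named here, compound 2 therefore holds the only number in the set; the other two entries sit at the limit of > 100000 nM in this assay, at which 2 of the 3 values shown sit. Going by the values given here, the one step that can be drawn, a step that the two limits leave unreadable from compound 1 to compound 3, runs between two limits, so its size is not readable.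

Compound 4, `COc1ccc(CNC(=O)/C=C/c2coc3cc(OC)ccc3c2=O)cc1`, differs from compound 2 by 4-methoxyphenyl in place of 3-fluorophenyl on a saturated chain carbon bound to an amide-type nitrogen. Among the compounds with values here, no measured step exchanges a fluorine for a methoxy on this part of the molecule, and the one step that does alter the amide substituent cannot be sized, so none of the measured steps bears directly on this change.

In this assay compound 4 is therefore expected to stay near compound 2. The step of a 1.3-fold higher number from compound 2 to compound 4 (0.11 log units; within the scatter) is estimated to lie within the scatter, with the possibility of a return to the limit kept open. The estimate for compound 4 is 35000 nM, within 9000 nM to 140000 nM.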

Compound 4, half-maximal inhibitory concentration: 22500 nM
For compound 4 the middle estimate is 1.6-fold (0.19 log units) above the measured one; low and high end bracket the measured number.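

In this assay, for the compounds shown here, 4-methoxyphenyl in place of 3-fluorophenyl on a saturated chain carbon bound to an amide-type nitrogen gives a 1.2-fold lower number from compound 2 to compound 4 (0.08 log units; within the scatter), the first step on this substituent that can be read, since the earlier one ran between two limits. For these two compounds, the benzyl group on the amide-type nitrogen can therefore carry either the fluorine or the methoxy group with no difference readable beyond the scatter, and the series now holds two numbers rather than one. Compound 1 and compound 3 remain limits of the assay and not numbers: the limit of > 100000 nM in this assay, at which 2 of the 4 values shown sit.

The exchange alters both the group and its place on the ring, so the compounds shown do not separate the two changes, and no pair isolates the hydroxy or methoxy group on the core. Also open, as far as these compounds go, is whether an amine or a carboxylic acid on the benzyl ring, or a longer chain in place of the benzyl carbon, would move the number beyond the scatter.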